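A few compounds are considered here, and "the series" means these few. Any claim that something is new, unique, unknown or untested is made for them only; others in the source may bear on it.

Measured in a functional assay on DU-145 cells (Homo sapiens) for inhibition, read by trypan blue exclusion, with a stated time of 96 h; a lower number here means a stronger inhibitor of growth, a higher number a weaker inhibitor of growth:
- compound 1 `Cc1ccc(CS(=O)(=O)/C(=C/c2c[nH]c3ccccc23)C(=O)c2ccc(Cl)cc2)cc1`: 25000 nM
- compound 2 `Cc1ccc(CS(=O)(=O)/C(=C/c2c[nH]c3ccc(Br)cc23)C(=O)c2ccc(Cl)cc2)cc1`: 10000 nM

Compound 2 holds the lower of these two numbers. Compound 3 `Cc1ccc(CS(=O)(=O)/C(=C/c2ccc(C)s2)C(=O)c2ccc(Cl)cc2)cc1` differs from it far more than compound 2 differs from compound 1: 5-methylthiophen-2-yl in place of 5-bromo-1H-indol-3-yl on a double-bonded chain carbon bound to a double-bonded chain carbon. For the measured compounds named here, the only measured step, a 2.5-fold lower number from compound 1 to compound 2 (0.40 log units; beyond the scatter), is modest and concerns the bromo alone. Going by the values given here, no measured step covers replacing 5-bromo-1H-indol-3-yl with 5-methylthiophen-2-yl, so no direction can be expected with confidence, and no change beyond the scatter is predicted. The expected step is a 1.2-fold higher number from compound 2 to compound 3 (0.08 log units; within the scatter), with wide uncertainty. For compound 3 the estimate in this assay is 12000 nM, with an expected range of 3000 nM to 50000 nM.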

Compound 3, concentration for 50% growth inhibition: 25000 nM
The estimate for compound 3 lay 2.1-fold (0.32 log units) below the measured number; the range from low to high includes it.
By their numbers in this assay, from the lowest: compound 2; then compounds 1 and 3 (each within the scatter of the next).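

In this assay, at this double-bonded chain carbon, 5-methylthiophen-2-yl does as well as plain 1H-indol-3-yl, with no change at the digits printed from compound 1 to compound 3 (within the scatter). It falls short of 5-bromo-1H-indol-3-yl, with a 2.5-fold higher number from compound 2 to compound 3 (0.40 log units; beyond the scatter), so among these three compounds the indole alone brings no advantage, and only the bromo-bearing compound 2 stands apart. Nothing available explains these results.

From the compounds shown here alone, it remains open whether a bromo on the thiophene would lower the number as it did on the indole. Going by these compounds, a phenyl ring carrying an amine or a carboxylic acid at this carbon also remains untested here.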